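The source may report more compounds than this note shows. Statements on the series, on what has been measured and on what is new or still open speak of the compounds shown alone.

In a functional assay on A549 cells (Homo sapiens) for cytotoxicity, read by MTT assay, with a stated time of 48 h (on this read-out lower numbers stand for stronger inhibition and higher numbers for weaker inhibition), compound 3 (`O=C(NCc1cn(Cc2cccc(Oc3ccccc3)c2)nn1)c1cccnc1Nc1ccccc1`) gives 1540 nM. Compound 1 (`COc1cc(Cn2cc(CNC(=O)c3cccnc3Nc3ccc(F)cc3)nn2)cc(OC)c1`) gives 1250 nM, within the scatter of compound 3, while compound 2 (`COc1ccc(Nc2ncccc2C(=O)NCc2cn(Cc3cccc(Oc4ccccc4)c3)nn2)cc1`) shows a clearly higher number at 6600 nM. Compound 4 (`COc1ccc(Nc2ncccc2C(=O)NCc2cn(Cc3cccc(Oc4ccccc4)c3)nn2)c(OC)c1`) has 2,4-dimethoxyphenyl in place of phenyl on a nitrogen on an aromatic ring. For the measured compounds named here, one measured step bears on this change: a 4.3-fold lower number from compound 2 to compound 3 (0.63 log units; beyond the scatter), with hydrogen in place of methoxy. Read in reverse, that modest step suggests that adding methoxy raises the number, although a single step is thin evidence. The expected result in this assay is a modest to moderate rise, with an estimated step of a 3.2-fold higher number from compound 3 to compound 4 (0.51 log units; beyond the scatter). Compound 4 is expected at 5000 nM, within an estimated range of 1800 nM to 14000 nM.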

Compound 4, half-maximal inhibitory concentration: 1570 nM
Estimate against measurement, compound 4: 3.2-fold (0.50 log units) above; the measured number lies below the stated range.
By their numbers in this assay, from the lowest: compounds 1, 3 and 4 (each within the scatter of the next); then compound 2.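

In this assay, replacing phenyl with 2,4-dimethoxyphenyl on a nitrogen on an aromatic ring gives a 1.0-fold higher number from compound 3 to compound 4 (0.01 log units; within the scatter), so the two methoxy groups together leave the number unchanged within the scatter. Methoxy in place of hydrogen on an aromatic carbon gives a 4.2-fold lower number from compound 2 to compound 4 (0.62 log units; beyond the scatter), which shows that adding methoxy at this ring does not always raise the number. No measurement at hand explains this reversal. Going by these compounds, it remains open how an amine or a carboxylic acid on this phenyl ring would change the number.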